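The source may hold more compounds than are shown below. What is called first, only, known or untested is meant among the compounds shown, and "the series" means these compounds.

Notes on the series. Compound 1 `Cc1ccc(C(=O)Nc2ncc(C(Oc3ccc4cc(Br)ccc4c3)c3ccc(Cl)cc3)s2)cc1` and compound 2 `N#Cc1cccc(C(=O)Nc2ncc(C(Oc3ccc4cc(Br)ccc4c3)c3ccc(Cl)cc3)s2)c1` share a core and differ only in the acyl group on the ring nitrogen. In an ADME assay on HepG2 2.2.15 cells (Homo sapiens) for cytotoxicity (on this read-out higher numbers stand for lower toxicity in this test and lower numbers for higher toxicity in this test), compound 1 gives "not toxic" (no number reported), without a number. In this assay compound 2 reaches only a limit of the test, at > 50000 nM, so no single number stands for it. Both entries thus point the same way; one of the two values sits at the limit (the limit of > 50000 nM in this assay, at which 1 of the 2 values shown sits), and nothing in the set gives a measured step in this assay.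

Compound 3 `O=S(=O)(Nc1ncc(C(Oc2ccc3cc(Br)ccc3c2)c2ccc(Cl)cc2)s1)c1cccs1` is not yet measured. It differs from compound 2 by (thiophen-2-yl)sulfonyl in place of (3-cyanophenyl)carbonyl on a nitrogen on an aromatic ring. Within the data shown here, no step between measured compounds exists for this change, so the expectation rests on the shared core alone. The step from compound 2 to compound 3 in this assay is expected to be none beyond the scatter, a step that the limit leaves unreadable from compound 2 to compound 3. Compound 3 is estimated at 60000 nM, within 20000 nM to 200000 nM, most likely again reported as a limit.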

Compound 3, half-maximal cytotoxic concentration: "not toxic" (no number reported)
For compound 3 the study gives words and no number; no gap can be computed for the estimate.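

In this assay, among these compounds, compound 3 gives "not toxic" (no number reported), so no step from compound 2 to compound 3 can be read. Compound 2 gives > 50000 nM, which is a limit of the test. The compounds shown leave open at what concentration, if any, cytotoxicity would appear for any of them.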